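The source may report more compounds than this note shows. Statements on the series, on what has been measured and on what is new or still open speak of the compounds shown alone.

Of the compounds shown here, three have numbers so far in a functional assay on the whole organism with Mus musculus as the target; on this read-out higher numbers stand for an effect only at larger amounts of compound and lower numbers for an effect already at smaller amounts: compound 1 (`C/C(=C\C(=O)NC1CC1)c1cccc(F)c1`) gives 122 mg/kg, compound 2 (`CNC(=O)/C=C1\CCc2cc(F)c(F)cc21`) gives 96 mg/kg, and compound 3 (`CCNC(=O)/C=C1\CCc2ccc(F)cc21`) gives 70 mg/kg. Compound 3 stands within the usual scatter of both other compounds, so these numbers do not separate the three.

Compound 4 (`CCN(C)C(=O)/C=C1\CCc2ccc(F)cc21`) keeps the core of compound 3 and differs in one place: methyl in place of hydrogen on an amide-type nitrogen. For the measured compounds named here, no two measured compounds differ in only one place, so no measured step bears directly on this change. All three measured compounds also carry the amide hydrogen, which leaves the series without a measured example of its replacement.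

Going by the values given here, the only guide is the narrow spread of the values despite the structural differences, with compound 1 at 122 mg/kg and compound 3 at 70 mg/kg. A large step is therefore not expected. The expected change in this assay, a 1.3-fold higher number from compound 3 to compound 4 (0.11 log units; within the scatter), is small, leans toward a higher number and stays within the scatter. For compound 4 the estimated value is 90 mg/kg, with an expected range from 40 mg/kg to 200 mg/kg.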

Compound 4, dose for half-maximal effect: 100 mg/kg
The estimate for compound 4 lay 1.1-fold (0.05 log units) below the measured number; low and high end bracket the measured number.
By their numbers in this assay, from the lowest: compounds 3, 2, 4 and 1 (each within the scatter of the next).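

For the compounds shown here, this is the first step that can be read at a single position: in this assay, methyl in place of hydrogen on the amide-type nitrogen gives a 1.4-fold higher number from compound 3 to compound 4 (0.15 log units; within the scatter) and so stays within the scatter. Compound 4 has no amide hydrogen and still gives 100 mg/kg in this assay, so the series now holds a measured example of this replacement, and at this level of resolution the ethylamino to ethyl(methyl)amino change does not separate the pair. No measurement here explains this outcome.

The reading rests on a single pair with the ethyl group on the nitrogen and the shared core held constant, so it does not show whether the same replacement would read alike on the cyclopropyl amide of compound 1 or the methyl amide of compound 2. Also open, going by these compounds, is whether this nitrogen would tolerate something larger than methyl, such as a longer chain like n-butyl, a benzyl group, or a pyrrolidine ring that takes in the nitrogen itself.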